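This account rests on a few compounds, and the source may have more. Where it says the series, first, only, none or still open, it means among the compounds named here.

Measured compounds in a functional assay on C6 cells (Rattus norvegicus) for cytotoxicity, read by MTT assay, with a stated time of 24 h, tested at 25 ug/mL; a higher number here means a weaker effect of the compound at the concentration tested, a lower number a stronger effect:
- compound 1 `Cc1ccc(-c2cs/c(=N/NC(=O)CSc3nncn3C)n2-c2ccccc2)cc1` gives 70.7%
- compound 2 `Cn1cnnc1SCC(=O)N/N=c1/scc(-c2ccc(C#N)cc2)n1-c1ccccc1` gives 58.8%
- compound 3 `Cn1cnnc1SCC(=O)N/N=c1/scc(-c2ccccc2)n1-c1ccccc1` gives 77.3%

Compound 1 stands second highest of the three numbers. Its nearest neighbour is compound 3, where a number 6.6 percentage points higher from compound 1 to compound 3 (within the scatter), a step within the scatter, and its furthest is compound 2, where a number 11.9 percentage points lower from compound 1 to compound 2 (beyond the scatter). Between compound 2 and compound 3 the step is a number 18.5 percentage points higher from compound 2 to compound 3 (beyond the scatter). All three measured steps concern the substituent on the aromatic carbon of the shared core; none touches the group carried on the sulfur.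

Compound 4 `Cc1ccc(-c2cs/c(=N/NC(=O)CSc3ncccn3)n2-c2ccccc2)cc1` differs from compound 1 by pyrimidin-2-yl in place of 4-methyl-4H-1,2,4-triazol-3-yl on a sulfur. Going by the values given here, no measured step in this assay bears on a change at that position, so there is no basis in the numbers for expecting a shift either way. The expectation is therefore a step of no size beyond the scatter, a number 0.7 percentage points lower from compound 1 to compound 4 (within the scatter), with a range widened for the lack of any comparable step. Compound 4 is estimated at 70%, between 55% and 85%.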

Compound 4, a percentage reported as activity, at one concentration (the size of the read-out at that concentration, not a potency): 82.7%
Estimate against measurement, compound 4: 12.7 percentage points below; measured number inside the range.
By their numbers in this assay, from the lowest: compound 2; then compounds 1, 3 and 4 (each within the scatter of the next, the first and the last beyond it).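

The group on the sulfur is not silent in this assay: pyrimidin-2-yl in place of 4-methyl-4H-1,2,4-triazol-3-yl gives a number 12 percentage points higher from compound 1 to compound 4 (beyond the scatter) and so a weaker effect at the concentration tested, which makes this a second place, after the substituent on the aromatic carbon, where the read-out moves. The step is modest and rests on a single pair, so it is tied to the methyl-bearing core of compound 1. No measurement on hand says why the read-out moves with this exchange.

Open, from the compounds shown here alone, is whether a phenyl or a pyridin-2-yl on the sulfur would read like pyrimidin-2-yl or like 4-methyl-4H-1,2,4-triazol-3-yl. Also open, going by these compounds, is whether the exchange gives a similar step with the cyano group of compound 2 in place of the methyl.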